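Swapping the Cap Group on a Hydroxamate Antiproliferative

The compounds below may be only part of what the source reports. "The series", "measured", "known", "first", "only" and "open" are said of these compounds alone.

Compound 1 `CN(C)c1ccc(C(=O)N[C@@H](CCCCCC(=O)NO)C(=O)NCc2ccccc2)cc1` is a hydroxamic acid that stops melanoma cells from multiplying. Going by the values given here, in a functional assay on MM96L cells (Homo sapiens) for antiproliferative activity (a lower number here means a stronger inhibitor, a higher number a weaker inhibitor), compound 1 gives 1600 nM, the lowest of the two numbers measured so far, while compound 2 `CC(C)CCNC(=O)C(CCCCCC(=O)NO)NC(=O)c1cccnc1` gives 9000 nM. Compound 3 `O=C(/C=C/c1c[nH]c2ccccc12)N[C@@H](CCCCCC(=O)NO)C(=O)NCc1ccccc1` differs from compound 1 in one place: 2-(1H-indol-3-yl)ethenyl in place of 4-(dimethylamino)phenyl on a carbonyl carbon. Among the compounds with values here, with no measured step of this kind to lean on, the expected step is a modest gain in potency, a 2.7-fold lower number from compound 1 to compound 3 (0.43 log units; beyond the scatter), which lies beyond the scatter but not far. Compound 3 is therefore estimated at 600 nM, with a range from 150 nM to 2500 nM.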

Compound 3, half-maximal inhibitory concentration: 3240 nM
Estimate against measurement, compound 3: 5.4-fold (0.73 log units) below, and the stated range ends below it.
By their numbers in this assay, from the lowest: compound 1; then compound 3; then compound 2.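

In this assay the group on this carbonyl carbon can be changed substantially without abolishing activity: 2-(1H-indol-3-yl)ethenyl in place of 4-(dimethylamino)phenyl gives a 2.0-fold higher number from compound 1 to compound 3 (0.31 log units; beyond the scatter), a modest loss just beyond the usual scatter. Going by these compounds alone, the larger group, with its two aromatic rings and a double bond outside them, therefore brings no gain over the single ring of compound 1. No available evidence explains this step. From the compounds shown here alone, whether a plain phenyl ring or a simple methyl group on this carbonyl carbon would match compound 1 remains open. So does the effect of a basic amine chain there.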